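Furan for thiophene on a shared nucleoside core

The compounds below may be only part of what the source reports. "The series", "measured", "known", "first", "only" and "open" are said of these compounds alone.

Compound 1, `COc1ncnc2c1c(-c1ccoc1)cn2[C@@H]1O[C@H](CO)[C@@H](O)[C@H]1O`, in a functional assay on CCRF-CEM cells (Homo sapiens), read by MTT assay, with a stated time of 72 h (a higher number here means a weaker inhibitor, a lower number a stronger inhibitor), gives 110 nM.
Compound 2, `COc1ncnc2c1c(-c1cccs1)cn2[C@@H]1O[C@H](CO)[C@@H](O)[C@H]1O`, gives 90 nM.
Compound 3, `Nc1nc2c(c(-c3cccs3)cn2[C@@H]2O[C@H](CO)[C@@H](O)[C@H]2O)c(=O)[nH]1`, gives only a limit of the assay, > 20000 nM.

Compounds 1 and 2 carry the same core and differ by furan-3-yl in place of thiophen-2-yl on an aromatic carbon; the step of a 1.2-fold higher number from compound 2 to compound 1 (0.09 log units; within the scatter). Compound 3 has a different core; how the two cores differ is not broken down here. Compound 3 sits at the limit noted in the limit of > 20000 nM in this assay, at which 1 of the 3 values shown sits.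

Compound 4, `Nc1nc2c(c(-c3ccoc3)cn2[C@@H]2O[C@H](CO)[C@@H](O)[C@H]2O)c(=O)[nH]1`, is not yet measured. It differs from compound 3 by furan-3-yl in place of thiophen-2-yl on an aromatic carbon, the same change as that from compound 2 to compound 1. Since compound 3 gives only a limit and the same change in compound 2 to compound 1 stayed within the scatter, compound 4 is expected to give 30000 nM, between 10000 nM and 100000 nM. This estimate means a step that the limit leaves unreadable from compound 3 to compound 4, resting on a 1.2-fold higher number from compound 2 to compound 1 (0.09 log units; within the scatter).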

Compound 4, half-maximal inhibitory concentration: 17900 nM
Compound 4: middle estimate off by 1.7-fold (0.22 log units), on the high side, and the stated range covers the measured number.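

On the second core, in this assay, furan-3-yl in place of thiophen-2-yl gives an at least 1.1-fold lower number from compound 3 to compound 4 (0.04 log units; that floor lies within the scatter). Set beside the first core, the two readings compare as follows: the same change on two cores in this assay, a 1.2-fold higher number (0.09 log units; within the scatter) from compound 2 to compound 1 and an at least 1.1-fold lower number (0.04 log units; that floor lies within the scatter) from compound 3 to compound 4; the limit leaves it open whether they differ Compound 3 stands at a limit of the assay, so the data do not show that the change carries over from one core to the other with the same size, only that neither readable figure goes beyond the scatter: the limit of > 20000 nM in this assay, at which 1 of the 4 values shown sits.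

The compounds shown leave open what a phenyl ring or an amine in place of the furan-3-yl would do on either core. They also leave open whether furan-2-yl would behave as furan-3-yl does.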